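Hydroxy in place of cyano in the growth inhibition series

The source may report more compounds than this note shows. Statements on the series, on what has been measured and on what is new or still open speak of the compounds shown alone.

Measured in a functional assay on PC-3 cells (Homo sapiens); a lower number here means a stronger inhibitor of growth, a higher number a weaker inhibitor of growth:
Compound 1 `N#Cc1ccc(/C=C/S(=O)(=O)Cc2ccc(Nc3ncnc4ccccc34)cc2)cc1`: > 100000 nM (a limit)
Compound 2 `CC(C)(C)c1cc(/C=C/S(=O)(=O)Cc2ccc(Nc3ncnc4ccccc34)cc2)cc(C(C)(C)C)c1O`: 7000 nM
Compound 3 `O=S(=O)(/C=C/c1ccc(C(F)(F)F)cc1F)Cc1ccc(Nc2ncnc3ccccc23)cc1`: 100000 nM

Compound 1 stands at > 100000 nM, which is a limit of the assay and not a number. Its only place on the scale is the limit of > 100000 nM in this assay, at which 1 of the 3 values shown sits.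

Compound 4 `O=S(=O)(/C=C/c1ccc(O)cc1)Cc1ccc(Nc2ncnc3ccccc23)cc1` has not yet been measured. It departs from compound 1 by hydroxy in place of cyano on an aromatic carbon, with hydroxy in place of cyano on an aromatic carbon, para to a large group.

Within the data shown here, the only measured step from compound 1 is a number no higher from compound 1 to compound 3 (the limit leaves the size open). It brings in no hydroxy group and its size cannot be read, so it gives little guidance. Among the measured compounds shown here, compound 2, at 7000 nM, is the only measured compound with a hydroxy group, but it also carries further groups that compound 4 lacks. Only part of that standing is expected to carry over.

The expected step is an at least 3.3-fold lower number from compound 1 to compound 4 (0.52 log units; beyond the scatter), an estimate toward a lower number in this assay. For compound 4 the estimated value is 30000 nM, with an expected range of 6000 nM to 100000 nM.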

Compound 4, concentration for 50% growth inhibition: 14000 nM
Estimate against measurement, compound 4: 2.1-fold (0.33 log units) above; low and high end bracket the measured number.
By their numbers in this assay, from the lowest: compounds 2 and 4 (each within the scatter of the next); then compound 3.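

At this position, on an aromatic carbon para to a large group, hydroxy alone, with no further groups on that ring, brings a clear change in this assay: the swap from cyano gives an at least 7.1-fold lower number from compound 1 to compound 4 (0.85 log units; beyond the scatter). Among these compounds, the swap of 2-fluoro-4-(trifluoromethyl)phenyl for 4-hydroxyphenyl gives a 7.1-fold lower number from compound 3 to compound 4 (0.85 log units; beyond the scatter), and this step, unlike the one from the cyano compound, has a readable size. Compound 1 remains a limit and not a number, which leaves the upper size of its step open: the limit of > 100000 nM in this assay, at which 1 of the 4 values shown sits.

Open, from the compounds shown here alone, is whether a methoxy group, an amine or a carboxylic acid at this position would match hydroxy. Also open, going by these compounds, is whether the number follows the hydrogen-bond donor that hydroxy brings or simply the departure of cyano.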